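The source may hold more compounds than are shown below. What is called first, only, known or untested is meant among the compounds shown, and "the series" means these compounds.

Of the compounds shown here, three built on one shared core have been measured in an assay on isolated protein for displacement of a labelled ligand from metabotropic glutamate receptor 5 (Homo sapiens), with a stated time of 60 min, tested at 1 uM; on this read-out lower numbers stand for less inhibition and higher numbers for more inhibition at the one concentration tested (going by the name of the read-out). Compound 1 `CC1CCN(c2c(S(=O)(=O)c3cc(Cl)cc(Cl)c3)cnc3ccc(Cl)cc23)CC1` gives 88% in this assay, and compound 3 `CC1CCN(c2c(S(=O)(=O)c3ccc(F)cc3)cnc3ccc(Cl)cc23)CC1` gives 89%, the two differing only by a number 1 percentage points higher from compound 1 to compound 3 (within the scatter), which lies within the scatter. Compound 2 `Cc1ccc(S(=O)(=O)c2cnc3ccc(Cl)cc3c2N2CCC(C)CC2)cc1F` gives 68%, the lowest of the three numbers: it sits a number 20 percentage points lower from compound 1 to compound 2 (beyond the scatter) and a number 21 percentage points higher from compound 2 to compound 3 (beyond the scatter), both steps beyond the scatter, though modest. All three measured steps concern the aryl group on the sulfonyl sulfur and nothing else.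

Compound 4 `COc1ccc2ncc(S(=O)(=O)c3ccc(C)c(F)c3)c(N3CCC(C)CC3)c2c1` differs from compound 2 in one place: methoxy in place of chloro on an aromatic carbon. This change sits on the fused carbon ring of the core, meta to a fused ring and para to a fused ring, while the 3-fluoro-4-methylphenyl on the sulfonyl sulfur is kept. For the measured compounds named here, no measured step touches this position, so the three steps give no direct guide to the size or direction of the effect; they only show that changes elsewhere on the shared core have left the number higher, lower or level within a modest span. With no evidence for a shift, compound 4 is expected to stay near compound 2, giving an estimated 63% in this assay, within a range of 40% to 83%. As far as these compounds go, the expected change from compound 2 to compound 4 is therefore a number 5 percentage points lower from compound 2 to compound 4 (within the scatter), with the wide range reflecting that this position is untested.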

Compound 4, a percentage reported as inhibition, at one concentration (the size of the read-out at that concentration, not a potency): 73%
For compound 4 the middle estimate is 10 percentage points below the measured one; the range from low to high includes it.
By their numbers in this assay, from the lowest: compounds 2 and 4 (each within the scatter of the next); then compounds 1 and 3 (each within the scatter of the next).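

For the compounds shown here, this is the first step at this position, on the fused carbon ring of the core, meta to a fused ring and para to a fused ring. In this assay, going by these compounds alone, methoxy in place of chloro gives a number 5 percentage points higher from compound 2 to compound 4 (within the scatter), so with the 3-fluoro-4-methylphenyl kept on the sulfonyl sulfur, the position accepts this swap of a single chlorine for a two-heavy-atom group carrying a hydrogen-bond acceptor without a shift beyond the scatter, whereas the earlier steps spoke only of the aryl group on the sulfonyl sulfur. Nothing available accounts for this outcome or tells what either group does at this position.

The compounds shown offer only this one pair at the position, so it remains open whether the same swap would read alike with the 4-fluorophenyl of compound 3 or the 3,5-dichlorophenyl of compound 1 on the sulfonyl sulfur. Also open, as far as these compounds go, is what a different group would give here, such as an amine, a carboxylic acid, a nitrile or a longer chain like propoxy.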